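Notes on a fused bicyclic series with varied imine substituents

The source may hold more compounds than are shown below. What is called first, only, known or untested is meant among the compounds shown, and "the series" means these compounds.

Three members carry measured numbers. In a functional assay on MDA-MB-231 cells (Homo sapiens) for antiproliferative activity, read by sulforhodamine B assay (a lower number here means a stronger inhibitor of growth, a higher number a weaker inhibitor of growth), compound 1 `CC(C)C1CC(=O)c2s/c(=N/c3ccccc3)oc2C1` gives 2480 nM. Compound 2 `CC1(C)CC(=O)c2s/c(=N/C3CCCCC3)oc2C1` gives 13100 nM in this assay. For compound 3 `CC1(C)CC(=O)c2s/c(=N/c3c(Cl)cc(Cl)cc3Cl)oc2C1` this assay gives > 30000 nM, which is a limit of the assay rather than a number, so compound 3 stands at the limit of > 30000 nM in this assay, at which 1 of the 3 values shown sits. The change leading to compound 4 `CC1CC(=O)c2s/c(=N/c3c(Cl)cc(Cl)cc3Cl)oc2C1` is hydrogen in place of methyl on a saturated ring carbon. Within the data shown here, no measured pair shows this change on its own. The step is expected to be small, in no set direction, and not beyond the scatter: a number no higher from compound 3 to compound 4 (the limit leaves the size open). Compound 4 is therefore estimated at about 30000 nM, with a range from 10000 nM to 100000 nM, and a fair chance that the assay again reports only a limit.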

Compound 4, concentration for 50% growth inhibition: > 30000 nM
Compound 4 ended at the assay's limit; the forecaster's own chance of this, stated with the estimate: 55%; the middle value lies on the limit itself.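

Compound 3 and compound 4 both sit at the assay's limit, so no step can be read between them: the limit of > 30000 nM in this assay, at which 2 of the 4 values shown sit.

The compounds shown leave open whether hydrogen in place of methyl on a saturated ring carbon changes the result in this assay where values fall clear of the limit.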